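This account rests on a few compounds, and the source may have more. Where it says the series, first, only, none or still open, it means among the compounds named here.

Compound 1 `N#CC1=C(N)Oc2c(c3nc4ccccc4nc3c3ccccc23)C12C(=O)N(Cc1cnnn1-c1ccc(F)cc1)c1ccccc12` carries a fluoro on an aromatic carbon. In an ADME assay on L02 cells (Homo sapiens) for antiproliferative activity, read by MTT assay, with a stated time of 48 h (on this read-out lower numbers stand for stronger inhibition and higher numbers for weaker inhibition), compound 1 gives > 50000 nM, which is a limit of the assay rather than a number. Compound 2 `N#CC1=C(N)Oc2c(c3nc4ccccc4nc3c3ccccc23)C12C(=O)N(Cc1cnnn1-c1ccc(Cl)cc1)c1ccccc12` differs from it by chloro in place of fluoro on an aromatic carbon. In this assay compound 2 gives > 50000 nM, again a limit. The step that the two limits leave unreadable from compound 1 to compound 2 therefore cannot be read. Compound 3 `N#CC1=C(N)Oc2c(N)cc3nc4ccccc4nc3c2C12C(=O)N(Cc1cnnn1-c1ccc(F)cc1)c1ccccc12` rests on a different core; the difference between the two cores is not broken down here. In this assay compound 3 gives > 50000 nM, also a limit. All three results share (the limit of > 50000 nM in this assay, at which 3 of the 3 values shown sit). Compound 4 `N#CC1=C(N)Oc2c(N)cc3nc4ccccc4nc3c2C12C(=O)N(Cc1cnnn1-c1ccc(Cl)cc1)c1ccccc12` has not yet been measured; it differs from compound 3 by chloro in place of fluoro on an aromatic carbon, the same change that turns compound 1 into compound 2, at the same place. The expected step is a step that the limit leaves unreadable from compound 3 to compound 4 because compound 3 gives > 50000 nM. That expectation rests on compound 1 and compound 2 both sitting at the limit of > 50000 nM in this assay, at which 3 of the 3 values shown sit. Compound 4 is expected to give about 80000 nM, most likely between 20000 nM and 300000 nM.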

Compound 4, half-maximal inhibitory concentration: > 50000 nM
Compound 4: a limit, no number (the forecaster's own chance of this, stated with the estimate: 85%); the middle value does not contradict the limit.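

In this assay compound 4 gives > 50000 nM, which is a limit of the assay and not a number. Compound 3 also sits at a limit, so the step from compound 3 to compound 4 cannot be read. The compounds shown leave open what any of their actual values is, and whether chloro in place of fluoro changes anything in this read-out: the limit of > 50000 nM in this assay, at which 4 of the 4 values shown sit.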